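The compounds below may be only part of what the source reports. "The series", "measured", "known", "first", "only" and "open" are said of these compounds alone.

Compound 1 `O=C(Nc1cccc(/C=C/C(=O)c2nc3ccccc3[nH]2)c1)c1ccc(Cl)cc1`: 8410 nM
Compound 2 `COc1cccc(C(=O)Nc2cccc(/C=C/C(=O)c3nc4ccccc4[nH]3)c2)c1`: 17800 nM

In a functional assay on MCF7 cells (Homo sapiens) for antiproliferative activity, read by MTT assay, with a stated time of 48 h (a lower number here means a stronger inhibitor, a higher number a weaker inhibitor), compound 1 gives 8410 nM, the lowest of the two numbers, while compound 2 gives 17800 nM. Among the compounds with values here, the only measured step, a 2.1-fold higher number from compound 1 to compound 2 (0.33 log units; beyond the scatter), alters the aryl group on the carbonyl carbon and leaves the carbonyl in place. Compound 3 `Cc1cccc(S(=O)(=O)Nc2cccc(/C=C/C(=O)c3nc4ccccc4[nH]3)c2)c1` arises from compound 1 by (3-methylphenyl)sulfonyl in place of (4-chlorophenyl)carbonyl on a nitrogen on an aromatic ring. Within the data shown here, no measured pair covers a change of the carbonyl to a sulfonyl, so the expectation rests on the one modest step alone. Compound 3 is expected to show a step of a 1.8-fold higher number from compound 1 to compound 3 (0.25 log units; within the scatter), a modest rise in the same direction as the measured one. Compound 3 is estimated at 15000 nM, between 5000 nM and 45000 nM.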

Compound 3, half-maximal inhibitory concentration: 886 nM
For compound 3 the middle estimate is 17-fold (1.23 log units) above the measured one; the whole stated range lies above it.
By their numbers in this assay, from the lowest: compound 3; then compound 1; then compound 2.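

On the nitrogen on an aromatic ring, the change to (3-methylphenyl)sulfonyl moves this assay much further than the aryl change on the carbonyl did, with a 9.5-fold lower number from compound 1 to compound 3 (0.98 log units; beyond the scatter) and a 20-fold lower number from compound 2 to compound 3 (1.30 log units; beyond the scatter). This position therefore accepts a sulfonyl and gives the lowest number of the three compounds. Nothing available here accounts for the gain. The step changes both the carbonyl and the aryl group, so the contribution of each remains unresolved. A (4-chlorophenyl)sulfonyl or (3-methylphenyl)carbonyl group on this nitrogen would separate them.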